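This account rests on a few compounds, and the source may have more. Where it says the series, first, only, none or still open, it means among the compounds named here.

Compound 1 `CO[C@H]1C(=O)N2C(C(=O)C(C)(C)C)=C(C)C(Sc3nnc(C)s3)S(=O)(=O)[C@H]12`: 26 h
Compound 2 `CO[C@H]1C(=O)N2C(C(=O)C(C)(C)C)=C(C)CS(=O)(=O)[C@H]12`: 130 h
Compound 3 `CO[C@H]1C(=O)N2C(C(=O)C(C)(C)C)=C(CSc3nnnn3C)CS(=O)(=O)[C@H]12`: 24 h

In a physicochemical assay for pharmacokinetics, at 37 degrees C (a lower number here means that the compound disappears faster, a higher number that the compound lasts longer), compound 2 gives the highest number of the three. The nearest of the other two is compound 1, reached by a 5.0-fold higher number from compound 1 to compound 2 (0.70 log units; beyond the scatter) read in reverse; the furthest is compound 3, described by a 5.4-fold lower number from compound 2 to compound 3 (0.73 log units; beyond the scatter). Both of these steps remove or add a sulfanyl-linked heterocycle on a carbon of the shared core, and both are of modest size.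

Compound 4 `CO[C@H]1C(=O)N2C(C(=O)c3ccccc3)=C(C)CS(=O)(=O)[C@H]12` differs from compound 2 in one place: phenyl in place of tert-butyl on a carbonyl carbon. Neither measured step touches the carbonyl carbon or the group on it, so no step shown here bears directly on this change, and the two known steps only indicate the scale on which this assay has moved so far. Compound 4 is therefore expected to lie near compound 2, with a step of a 1.6-fold lower number from compound 2 to compound 4 (0.21 log units; within the scatter) that could fall in either direction. The estimate for compound 4 in this assay is 80 h, within a range from 25 h to 250 h.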

Compound 4, half-life: 33 h
Estimate against measurement, compound 4: 2.4-fold (0.38 log units) above; the range from low to high includes it.
By their numbers in this assay, from the lowest: compounds 3, 1 and 4 (each within the scatter of the next); then compound 2.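

In this assay the group on the carbonyl carbon proves to matter: phenyl in place of tert-butyl gives a 3.9-fold lower number from compound 2 to compound 4 (0.60 log units; beyond the scatter) and so moves the half-life beyond the scatter. The earlier steps shown here showed such movement only with the sulfanyl-linked heterocycles on the shared core, and this change, which involves no sulfur-linked group, is also modest in size. Nothing available accounts for this fall.

Going by these compounds, how a methyl, a cyclohexyl or a pyridyl group on the carbonyl carbon would compare with tert-butyl and phenyl stays open, so it cannot be said whether the fall belongs to phenyl in particular. Also open, on these data alone, is whether phenyl would have a similar effect alongside the heterocycles of compound 1 and compound 3, both of which carry tert-butyl.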